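A few compounds are considered here, and "the series" means these few. Any claim that something is new, unique, unknown or untested is made for them only; others in the source may bear on it.

Compound 1 `NS(=O)(=O)c1ccc(N2N=C(c3ccc(Oc4ccccc4)cc3)CC2c2cccc(F)c2)cc1`: 10000 nM
Compound 2 `Cc1ccc(C2CC(c3ccc(Oc4ccccc4)cc3)=NN2c2ccc(S(N)(=O)=O)cc2)cc1`: 8000 nM

For the measured compounds named here, in an ADME assay on BHK-21 cells (Mesocricetus auratus) for cytotoxicity, read by MTT assay, with a stated time of 72 h (on this read-out lower numbers stand for higher toxicity in this test and higher numbers for lower toxicity in this test), compound 2 gives 8000 nM, a value within the usual scatter of the only other measured compound, compound 1. Compound 3 `NS(=O)(=O)c1ccc(N2N=C(c3ccc(Oc4ccccc4)cc3)CC2c2cccc(Cl)c2)cc1` has 3-chlorophenyl in place of 4-methylphenyl on a saturated ring carbon. Going by the values given here, one measured step bears on this change, since it swaps the group on the same carbon: a 1.3-fold lower number from compound 1 to compound 2 (0.10 log units; within the scatter). That step stayed within the scatter, so no change beyond the scatter is expected in this assay. The expected step is a 1.1-fold higher number from compound 2 to compound 3 (0.05 log units; within the scatter). The estimate for compound 3 is 9000 nM, with an expected range of 4500 nM to 18000 nM.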

Compound 3, half-maximal cytotoxic concentration: 9000 nM
For compound 3 middle estimate and measured number coincide at the digits printed; the measured number falls inside the stated range.
By their numbers in this assay, from the lowest: compounds 2, 3 and 1 (each within the scatter of the next).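

In this assay, 3-chlorophenyl in place of 4-methylphenyl gives a 1.1-fold higher number from compound 2 to compound 3 (0.05 log units; within the scatter) and chloro in place of fluoro on the aromatic ring gives a 1.1-fold lower number from compound 1 to compound 3 (0.05 log units; within the scatter). Compound 3 thus adds a second halogen-bearing phenyl group and a direct chloro and fluoro comparison, and all three compounds on this saturated ring carbon remain within the scatter of one another. Nothing available explains this result. On these data alone, what remains open is whether a different kind of group on this carbon, such as an amine or a carboxylic acid, would produce a step beyond the scatter.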